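Aryl swap at the chain end of the labdane diol series

A few compounds are considered here, and "the series" means these few. Any claim that something is new, unique, unknown or untested is made for them only; others in the source may bear on it.

Compound 1 `CC1(C)CCC[C@]2(C)[C@@H](CC[C@@](C)(O)/C=C/c3cccc([N+](=O)[O-])c3)[C@](C)(O)CC[C@@H]12` is the reference point. Going by the values given here, in a functional assay on PC-3 cells (Homo sapiens) for cytotoxicity, read by MTT assay, with a stated time of 48 h (on this read-out lower numbers stand for stronger inhibition and higher numbers for weaker inhibition), compound 1 gives 153 nM, the lowest of the two numbers measured so far. Compound 2 `CC1(C)CCC[C@]2(C)[C@@H](CC[C@@](C)(O)/C=C/c3cncc4ccccc34)[C@](C)(O)CC[C@@H]12` gives 3900 nM, and the step of a 25-fold higher number from compound 1 to compound 2 (1.41 log units; beyond the scatter) shows that exchanging the aryl group on the chain is not neutral. Compound 3 `Cc1cccc(C)c1/C=C/[C@](C)(O)CC[C@@H]1[C@@]2(C)CCCC(C)(C)[C@@H]2CC[C@@]1(C)O` differs from compound 1 as follows: 2,6-dimethylphenyl in place of 3-nitrophenyl on a double-bonded chain carbon bound to a double-bonded chain carbon. Among the compounds with values here, only the step from compound 1 to compound 2 bears on this change, and it was large; a weakening step is therefore expected in this assay, though smaller. Compound 3 is estimated at 600 nM, range 150 nM to 3000 nM, a step of a 3.9-fold higher number from compound 1 to compound 3 (0.59 log units; beyond the scatter).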

Compound 3, half-maximal inhibitory concentration: 278 nM
Estimate against measurement, compound 3: 2.2-fold (0.33 log units) above, and the stated range covers the measured number.
By their numbers in this assay, from the lowest: compounds 1 and 3 (each within the scatter of the next); then compound 2.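

In this assay, the change at this place on the chain does not have to cost activity (a 1.8-fold higher number from compound 1 to compound 3 (0.26 log units; within the scatter)), so the nitrogen and oxygen atoms of 3-nitrophenyl are not required for a low number. The loss with isoquinolin-4-yl is therefore not a general result of replacing 3-nitrophenyl (a 14-fold lower number from compound 2 to compound 3 (1.15 log units; beyond the scatter)). No evidence is available that accounts for these differences. Still open, going by these compounds, is how an unsubstituted phenyl or a single methyl on the phenyl ring would read here. On these data alone, an aminophenyl or a carboxylic acid on that ring also remains open.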